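A few compounds are considered here, and "the series" means these few. Any claim that something is new, unique, unknown or untested is made for them only; others in the source may bear on it.

Three compounds share one core and differ only in the amine that sits on a saturated chain carbon bound to a carbonyl carbon. Compound 1 `COc1ccc(-c2cc3ccc(OC)cc3nc2Nc2ccc(NC(=O)CN(C)C)cc2)cc1` carries dimethylamino there, and in a functional assay on HUVEC cells (Homo sapiens) for antiproliferative activity, read by MTT assay, with a stated time of 48 h (a higher number here means a weaker inhibitor, a lower number a stronger inhibitor), compound 1 gives 9200 nM. Compound 2 `CCN(CC)CC(=O)Nc1ccc(Nc2nc3cc(OC)ccc3cc2-c2ccc(OC)cc2)cc1` carries diethylamino, and in this assay compound 2 gives 14000 nM. Compound 3 `COc1ccc(-c2cc3ccc(OC)cc3nc2Nc2ccc(NC(=O)CN3CCCC3)cc2)cc1` carries pyrrolidin-1-yl, and in this assay compound 3 gives 8600 nM, the lowest of the three numbers, although every step among them stays within the scatter: a 1.5-fold higher number from compound 1 to compound 2 (0.18 log units; within the scatter), a 1.1-fold lower number from compound 1 to compound 3 (0.03 log units; within the scatter), and a 1.6-fold lower number from compound 2 to compound 3 (0.21 log units; within the scatter). Compound 4 `COc1ccc(-c2cc3ccc(OC)cc3nc2Nc2ccc(NC(=O)CN3CCCCC3)cc2)cc1` is the next member of this set, and its change from compound 3 is piperidin-1-yl in place of pyrrolidin-1-yl on a saturated chain carbon bound to a carbonyl carbon. All three measured steps exchanged one amine for another at this same place, and none of them moved the number beyond the scatter, so the ring enlargement in compound 4 is expected to behave in the same way, with no step beyond the scatter in either direction. On that basis compound 4 is expected to give 9000 nM in this assay, with a range from 4500 nM to 18000 nM, which is expected to mean a step of a 1.0-fold higher number from compound 3 to compound 4 (0.02 log units; within the scatter).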

Compound 4, half-maximal inhibitory concentration: 23500 nM
Estimate against measurement, compound 4: 2.6-fold (0.42 log units) below, outside the stated range (above it).
By their numbers in this assay, from the lowest: compounds 3, 1, 2 and 4 (each within the scatter of the next, the first and the last beyond it).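

Within the data shown here, the three earlier steps suggested that in this assay this place tolerates any exchange of one amine for another, but the six-membered ring of piperidin-1-yl in place of the five-membered ring of pyrrolidin-1-yl gives the first step here beyond the scatter, though a modest one (a 2.7-fold higher number from compound 3 to compound 4 (0.44 log units; beyond the scatter)). Compound 4 is also separated from the dimethylamino member (a 2.6-fold higher number from compound 1 to compound 4 (0.41 log units; beyond the scatter)), whereas it cannot be told apart from the diethylamino member (a 1.7-fold higher number from compound 2 to compound 4 (0.22 log units; within the scatter)), so the amine at this place does matter, yet the weaker end of the set holds both an open-chain amine and a ring, and ring size alone does not sort these compounds. Nothing available here accounts for the change at this position.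

A single pair of rings cannot show whether a still larger ring, azepan-1-yl, would raise the number further, or whether morpholin-4-yl or 4-methylpiperazin-1-yl, which carry a second hetero atom in the ring, would behave like piperidin-1-yl or like pyrrolidin-1-yl. It also remains open whether a longer chain between the carbonyl and the amine would keep the same order among these amines.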